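The source may report more compounds than this note shows. Statements on the series, on what has been measured and on what is new or still open speak of the compounds shown alone.

Notes on the series. Three compounds have so far been run in a functional assay on Daoy cells (Homo sapiens) for cytotoxicity, read by MTT assay, with a stated time of 72 h; on this read-out higher numbers stand for weaker inhibition and lower numbers for stronger inhibition: compound 1 `COc1ccc(N(C)C(=O)N(C)c2cc(OC)c(OC)c(OC)c2)cc1`, compound 2 `COc1cc(N(C)C(=O)c2cccc(F)c2)cc(OC)c1OC` and compound 3 `COc1cc(N(C)C(=O)c2cccc([N+](=O)[O-])c2)cc(OC)c1OC`. In this assay compound 1 returns only the limit >= 125000 nM and no number. For compound 2 this assay likewise gives only the limit >= 125000 nM. For compound 3 this assay again gives only the limit >= 125000 nM. Compound 2 therefore cannot be placed against the others: its value is a limit, and the two further values shown are limits as well, all three sitting at the limit of >= 125000 nM in this assay, at which 3 of the 3 values shown sit. Among the measured compounds shown here, the single step among measured compounds, a step that the two limits leave unreadable from compound 2 to compound 3, is left unreadable by the two limits at its ends.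

Compound 4 `COc1ccc(C(=O)N(C)c2cc(OC)c(OC)c(OC)c2)cc1` remains to be measured in this assay. It differs from compound 2 by 4-methoxyphenyl in place of 3-fluorophenyl on a carbonyl carbon. For the measured compounds named here, no measured step bears on this change: the one step recorded, from compound 2 to compound 3, concerns a different pair of groups and cannot itself be read. With nothing pulling the expectation away from the limit, compound 4 is expected to return a limit once more rather than a number. The estimate for compound 4 is placed at 125000 nM, with a range from 50000 nM to 400000 nM. The expected step is accordingly a number no higher from compound 2 to compound 4 (the limit leaves the size open), none beyond the scatter.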

Compound 4, half-maximal inhibitory concentration: >= 125000 nM
Compound 4 gave a limit, no number (the forecaster's own chance of this, stated with the estimate: 85%); the middle value sits exactly at the limit.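

No step can be read between compound 2 and compound 4 in this assay, since both return only a limit and every value shown sits at the same point: the limit of >= 125000 nM in this assay, at which 4 of the 4 values shown sit.

The compounds shown leave open how far any of them lies from that limit, and which change to the shared core, if any, would yield a measurable number.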